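Replacing benzyl with 2,6-dichlorobenzyl in compound 2

This account rests on a few compounds, and the source may have more. Where it says the series, first, only, none or still open, it means among the compounds named here.

Going by the values given here, in a functional assay on DU-145 cells (Homo sapiens) for cytotoxicity, read by MTT assay (on this read-out lower numbers stand for stronger inhibition and higher numbers for weaker inhibition), compound 2 `COc1ccc2cc([C@H](C)c3nnc(SCc4ccccc4)n3-c3ccc(Cl)cc3)ccc2c1` gives 35800 nM, the only true number in this small set. Compound 1 `COc1cccc(CSc2nnc([C@@H](C)c3ccc4cc(OC)ccc4c3)n2-c2ccc(Cl)cc2)c1` gives <= 400000 nM, which is a limit of the assay. Compound 3 `COc1ccc(CSc2nnc([C@@H](C)c3ccc4cc(OC)ccc4c3)n2-c2ccc(F)cc2)cc1` gives <= 400000 nM, which is also a limit. The evidence is therefore thin: the limit of <= 400000 nM in this assay, at which 2 of the 3 values shown sit. Compound 2 cannot be ranked against either neighbour.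

Compound 4 `COc1ccc2cc([C@H](C)c3nnc(SCc4c(Cl)cccc4Cl)n3-c3ccc(Cl)cc3)ccc2c1` departs from compound 2 through one change: 2,6-dichlorophenyl in place of phenyl on a saturated chain carbon bound to a sulfur. In words, this is 2,6-dichlorophenyl in place of phenyl on a saturated chain carbon bound to a sulfur. Among the compounds with values here, the only measured step in the set is a step that the limit leaves unreadable from compound 1 to compound 2. It is a different change and offers no size to carry over. With no readable step to draw on, the expectation stays anchored to compound 2 at 35800 nM, and no shift beyond the scatter is predicted in this assay, in either direction. The expected step is a 1.2-fold lower number from compound 2 to compound 4 (0.08 log units; within the scatter). Compound 4 is estimated at 30000 nM, with an expected range of 8000 nM to 120000 nM.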

Compound 4, half-maximal inhibitory concentration: 36100 nM
Estimate against measurement, compound 4: 1.2-fold (0.08 log units) below; the range from low to high includes it.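

In this assay, exchanging phenyl for 2,6-dichlorophenyl on a saturated chain carbon bound to a sulfur gives a 1.0-fold higher number from compound 2 to compound 4 (0.00 log units; within the scatter). Going by these compounds alone, this is the only readable step in the set, and it shows that this position accepts the larger 2,6-dichlorophenyl group with no change in the read-out beyond the scatter. The step involving compound 1 cannot be read, so the evidence on the other substituents remains thin: the limit of <= 400000 nM in this assay, at which 2 of the 4 values shown sit.

The compounds shown leave open whether a different kind of group at this position, such as an amine or a carboxylic acid, would move the number beyond the scatter. They also leave open whether any change here could bring the value of compound 2 down by a readable margin.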